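This account rests on a few compounds, and the source may have more. Where it says the series, first, only, none or still open, it means among the compounds named here.

Measured compounds in a functional assay (trachea) with Cavia porcellus as the target; a lower number here means a stronger inhibitor, a higher number a weaker inhibitor:
- compound 1, `Cn1nc(-c2cccnc2)c2ccccc2c1=O`: 11500 nM
- compound 2, `C=CCn1nc(-c2cccnc2)c2ccccc2c1=O`: 2140 nM
- compound 3, `O=c1c2ccccc2c(-c2cccnc2)nn1Cc1ccccc1`: 2450 nM

Among these three, compound 2 gives the lowest number in this assay. Its nearest neighbour is compound 3, and a 1.1-fold higher number from compound 2 to compound 3 (0.06 log units; within the scatter) lies within the usual scatter, so the two cannot be told apart. Its furthest neighbour is compound 1, and a 5.4-fold lower number from compound 1 to compound 2 (0.73 log units; beyond the scatter) is a clear, modest step; a 4.7-fold lower number from compound 1 to compound 3 (0.67 log units; beyond the scatter) is of similar size.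

The next compound, compound 4, `O=C(c1cccs1)n1nc(-c2cccnc2)c2ccccc2c1=O`, carries a different change: (thiophen-2-yl)carbonyl in place of allyl on an aromatic nitrogen. Going by the values given here, no measured step touches an aromatic nitrogen directly. The two known steps only show that putting vinyl or phenyl on the saturated chain carbon lowers the number modestly, and that swapping one for the other changes nothing. Since the whole allyl chain leaves here, those steps give only weak guidance, and a step of modest size in either direction, or none beyond the scatter, is plausible.

For compound 4 the expected value in this assay is 3500 nM, with a range from 1200 nM to 12000 nM. This estimate means a step of a 1.6-fold higher number from compound 2 to compound 4 (0.21 log units; within the scatter), expected to stay small.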

Compound 4, half-maximal inhibitory concentration: 12300 nM
Compound 4: middle estimate off by 3.5-fold (0.55 log units), on the low side; the measured number lies above the stated range.
By their numbers in this assay, from the lowest: compounds 2 and 3 (each within the scatter of the next); then compounds 1 and 4 (each within the scatter of the next).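

Until now, every group on the aromatic nitrogen was joined through a saturated chain carbon, and in this assay allyl and benzyl gave lower numbers than methyl; (thiophen-2-yl)carbonyl, joined through a carbonyl, gives up that gain, with a 5.7-fold higher number from compound 2 to compound 4 (0.76 log units; beyond the scatter) and a 5.0-fold higher number from compound 3 to compound 4 (0.70 log units; beyond the scatter). Adding heavy atoms at this position therefore does not by itself lower the number, and compound 4 cannot be told apart from the methyl compound, with a 1.1-fold higher number from compound 1 to compound 4 (0.03 log units; within the scatter). No measurement here explains this loss.

The compounds shown cannot separate the part played by the carbonyl link from that of the thiophene ring. A thiophen-2-ylmethyl group, which keeps the ring on a saturated chain carbon, or a plain acetyl group, which keeps the carbonyl without the ring, would tell the two apart.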